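Aryl Swap at the Core: Naphthyl for Tolyl

This account rests on a few compounds, and the source may have more. Where it says the series, first, only, none or still open, it means among the compounds named here.

Three analogues built on one shared core have been measured in a functional assay on OVCAR-8 cells (Homo sapiens) for inhibition, read by sulforhodamine B assay, with a stated time of 48 h, tested at 10 uM; a higher number here means more inhibition at the concentration tested (going by the name of the read-out), a lower number less inhibition. Compound 1 `CC(=O)c1ccc(-c2cn3ccnc3c(-c3ccc4ncn(C5CCCCC5)c4c3)n2)cc1` gives 6.38%, compound 2 `Fc1ccccc1-c1cn2ccnc2c(-c2ccc3ncn(C4CCCCC4)c3c2)n1` gives 14.1%, and compound 3 `Cc1cccc(-c2cn3ccnc3c(-c3ccc4ncn(Cc5ccccc5)c4c3)n2)c1` gives 11.5%. Compound 3 is second highest of the three numbers, but its gap to compound 2 and its gap to compound 1 are both within the scatter, so no order among them can be claimed. Going by the values given here, the one measured step that changes the same aryl group, a number 7.7 percentage points higher from compound 1 to compound 2 (within the scatter), is also within the scatter.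

Compound 4 `c1ccc(Cn2cnc3ccc(-c4nc(-c5cccc6ccccc56)cn5ccnc45)cc32)cc1` has not yet been measured. It differs from compound 3 in one place: naphthalen-1-yl in place of 3-methylphenyl on an aromatic carbon. Among the compounds with values here, the only step that bears on this position, from compound 1 to compound 2, stayed within the scatter, so for compound 4 a step of no size beyond the scatter is expected in this assay, a number 0.5 percentage points higher from compound 3 to compound 4 (within the scatter). Compound 4 is therefore estimated at 12%, with a range from 2% to 30%.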

Compound 4, a percentage reported as inhibition, at one concentration (the size of the read-out at that concentration, not a potency): 6.22%
Compound 4: the middle estimate sits 5.8 percentage points above what was measured; low and high end bracket the measured number.
By their numbers in this assay, from the lowest: compounds 4, 1, 3 and 2 (each within the scatter of the next).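

Replacing 3-methylphenyl with naphthalen-1-yl adds a second six-membered aromatic ring of carbon only at this position and gives a number 5.3 percentage points lower from compound 3 to compound 4 (within the scatter) in this assay. The position has now been changed in compounds carrying the benzyl group as well as in those carrying the cyclohexyl group, and even this enlargement of the aryl group produced no step beyond the scatter. Nothing available explains the size of this step or connects it to any property of either group.

All the groups shown at this position are aromatic rings of carbon, with or without a small substituent. From the compounds shown here alone, whether an amine, a carboxylic acid or a ring containing nitrogen here would give a step beyond the scatter in this assay remains open.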